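The source may hold more compounds than are shown below. What is called first, only, known or untested is meant among the compounds shown, and "the series" means these compounds.

Measured so far in a functional assay on MCF7 cells (Homo sapiens) for cytotoxicity, read by ELISA, with a stated time of 4 days; on this read-out higher numbers stand for weaker inhibition and lower numbers for stronger inhibition:
- compound 1 `Clc1ccc(-c2cc(-c3ccoc3)cc(-c3ccco3)n2)s1`: 4740 nM
- compound 2 `Clc1cccc(-c2cc(-c3ccoc3)cc(-c3ccc(Cl)s3)n2)c1`: 2920 nM
- compound 3 `Clc1ccc(-c2cc(-c3ccoc3)cc(-c3ccccn3)n2)s1`: 3360 nM

Compound 3 cannot be ranked against the other two on these numbers. Its value sits with theirs, and its steps to both lie within the scatter: a 1.4-fold lower number from compound 1 to compound 3 (0.15 log units; within the scatter) and a 1.2-fold higher number from compound 2 to compound 3 (0.06 log units; within the scatter).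

Next is compound 4 `Clc1ccc(-c2cc(-c3ccoc3)cc(-c3cccnc3)n2)s1`, with pyridin-3-yl in place of pyridin-2-yl on an aromatic carbon.

Within the data shown here, no measured pair isolates this exact swap. The nearest evidence comes from the other changes at this same place, and even replacing the whole group moved little: a 1.6-fold lower number from compound 1 to compound 2 (0.21 log units; within the scatter), alongside the two steps above. On that basis, no step beyond the scatter is expected in this assay, and no direction can be favoured.

The estimate amounts to a 1.0-fold higher number from compound 3 to compound 4 (0.01 log units; within the scatter).

For compound 4 the expected value is 3400 nM, with an estimated range from 1800 nM to 6200 nM.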

Compound 4, half-maximal inhibitory concentration: 3480 nM
Beside the measured number, compound 4's estimate is 1.0-fold (0.01 log units) below it; the range from low to high includes it.
By their numbers in this assay, from the lowest: compounds 2, 3, 4 and 1 (each within the scatter of the next).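

In this assay, exchanging pyridin-2-yl for pyridin-3-yl on the carbon next to the ring nitrogen gives no readable change (a 1.0-fold higher number from compound 3 to compound 4 (0.02 log units; within the scatter)), so this swap adds a within-ring nitrogen shift to the changes already tested here without separating the compounds. Compound 4 also stays level with the two non-pyridine groups at this place (a 1.2-fold higher number from compound 2 to compound 4 (0.08 log units; within the scatter)) and (a 1.4-fold lower number from compound 1 to compound 4 (0.13 log units; within the scatter)), so furan-2-yl, 3-chlorophenyl, pyridin-2-yl and pyridin-3-yl all remain within the scatter of one another. Nothing measured on these compounds accounts for this flat result.

Open, from the compounds shown here alone, is whether this position stays as flat with a different kind of substituent, such as a primary amine, a carboxylic acid or a longer alkyl chain. Also open, going by these compounds, is how much the 5-chlorothiophen-2-yl and furan-3-yl groups, held constant in all four compounds, contribute.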